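A Fluoro for Nitro Swap at the Assay Limit

This account rests on a few compounds, and the source may have more. Where it says the series, first, only, none or still open, it means among the compounds named here.

In an ADME assay on MT4 cells (Homo sapiens) for cytotoxicity, read by MTT assay, with a stated time of 3 days (on this read-out higher numbers stand for lower toxicity in this test and lower numbers for higher toxicity in this test), three compounds have been measured: compound 1 (`CC(C)OC(=O)COC(=O)c1ccc([N+](=O)[O-])o1`), compound 2 (`O=C(COC(=O)c1ccc([N+](=O)[O-])o1)NC1CCc2ccccc21`) and compound 3 (`CC(C)(C)N(Cc1ccc([N+](=O)[O-])cc1)C(=O)COC(=O)c1ccc([N+](=O)[O-])o1`). Compound 1 gives > 100000 nM as a limit of the assay. Compound 2 gives > 100000 nM as a limit too. Compound 3 also gives only a limit, > 100000 nM and no number. That leaves the limit of > 100000 nM in this assay, at which 3 of the 3 values shown sit, as the whole of the evidence. Compound 4 (`CC(C)(C)N(Cc1ccc(F)cc1)C(=O)COC(=O)c1ccc([N+](=O)[O-])o1`) has fluoro in place of nitro on an aromatic carbon, para to a large group (fluoro in place of nitro on an aromatic carbon) on the same core. With only the limit of compound 3 to go on, no step beyond the scatter is expected in this assay and no direction is favoured. The estimated change reads a number no higher from compound 3 to compound 4 (the limit leaves the size open) and no more. For compound 4 the estimated value is 100000 nM with an expected range from 40000 nM to 200000 nM in this assay.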

Compound 4, half-maximal cytotoxic concentration: > 100000 nM
Compound 4: no number, only a limit; the forecaster's own chance of this, stated with the estimate: 70%; the middle value sits exactly at the limit.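

Compound 3 and compound 4 both give only a limit of the assay, and no step can be read between them. The compounds shown leave open what half-maximal cytotoxic concentration any of them has, and whether fluoro in place of nitro changes it: the limit of > 100000 nM in this assay, at which 4 of the 4 values shown sit.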